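From Methyl to Chloro at One Aromatic Carbon

The compounds below may be only part of what the source reports. "The series", "measured", "known", "first", "only" and "open" are said of these compounds alone.

Of the compounds shown here, two have so far been tested in an ADME assay on BEAS-2B cells (Homo sapiens) for cytotoxicity, read by MTT assay, with a stated time of 72 h; a higher number here means a weaker inhibitor of growth, a lower number a stronger inhibitor of growth. Compound 1 `N#C[Se]c1ccc(NC(=O)Oc2ccc(F)cc2)cc1` carries a fluoro group on an aromatic carbon, and in this assay compound 1 gives 19800 nM. Compound 2 `Cc1ccc(OC(=O)Nc2ccc([Se]C#N)cc2)cc1` has a methyl group at the same aromatic carbon, and in this assay compound 2 gives 5600 nM. Among the measured compounds shown here, the single measured step, a 3.5-fold lower number from compound 1 to compound 2 (0.55 log units; beyond the scatter), therefore moves the number downward by a modest amount. On the two numbers available, compound 2 stands lowest, which marks it as the stronger growth inhibitor of the pair.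

Compound 3 `N#C[Se]c1ccc(NC(=O)Oc2ccc(Cl)cc2)cc1` has not yet been measured. It differs from compound 2 in one place: chloro in place of methyl on an aromatic carbon. For the measured compounds named here, no measured step involves a chloro group, so the only guidance is the fluoro-to-methyl step, which shows that a single small group at this carbon can shift the number modestly. A change of similar size in either direction is plausible, and a return toward compound 1 cannot be excluded. The estimate for compound 3 in this assay is 8000 nM, with a range from 3000 nM to 25000 nM, which as a step means a 1.4-fold higher number from compound 2 to compound 3 (0.15 log units; within the scatter) is expected.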

Compound 3, concentration for 50% growth inhibition: 9300 nM
For compound 3 the middle estimate is 1.2-fold (0.07 log units) below the measured one; the range from low to high includes it.
By their numbers in this assay, from the lowest: compounds 2 and 3 (each within the scatter of the next); then compound 1.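

In this assay, among the compounds shown here, chloro in place of methyl on this aromatic carbon gives a 1.7-fold higher number from compound 2 to compound 3 (0.22 log units; within the scatter), so this read-out does not tell these two groups apart at this position, something the single fluoro-to-methyl step could not show. Chloro in place of fluoro gives a 2.1-fold lower number from compound 1 to compound 3 (0.33 log units; beyond the scatter), a modest step that only just clears the scatter, which makes methyl no longer the only group separated from fluoro here: among these three compounds, compound 1 stands apart, while compound 2 and compound 3 sit together. The data offer no measurement that could explain why fluoro stands apart from the other two groups.

For the compounds shown here, with only three groups at a single carbon, it remains open whether the separation of compound 1 is particular to fluoro or part of a wider trend, and how a methoxy group, an amine or a carboxylic acid would read at this position. Also open, from the compounds shown here alone, is whether chloro and methyl would still match on another carbon of the ring, or on a different core.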